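Trifluoromethyl for Ethyl on a Sulfonamide: Predicting Compound 4

The source may report more compounds than this note shows. Statements on the series, on what has been measured and on what is new or still open speak of the compounds shown alone.

Measured so far in an ADME assay on RAW264.7 cells (Mus musculus) for cytotoxicity, read by MTT assay, with a stated time of 48 h; a lower number here means a stronger inhibitor, a higher number a weaker inhibitor:
Compound 1, `CCS(=O)(=O)Nc1ccc(NC(=O)c2cc(C(F)(F)F)cc(C(F)(F)F)c2)cc1C`, gives 124000 nM.
Compound 2, `Cc1cc(NC(=O)c2cc(C(F)(F)F)cc(C(F)(F)F)c2)ccc1NS(=O)(=O)C(F)(F)F`, gives 40700 nM.
Compound 3, `CCS(=O)(=O)Nc1ccc(NC(=O)c2cccc(C(F)(F)F)c2)cc1Cl`, gives 62400 nM.

Compound 1 and compound 2 share a core and differ in one place: trifluoromethyl in place of ethyl on a sulfonyl sulfur. That single change gave a 3.0-fold lower number from compound 1 to compound 2 (0.48 log units; beyond the scatter) in this assay, a modest step but one beyond the usual scatter. Compound 3 has a different core from compound 1; the difference between the two cores is not broken down here. The value of compound 3 sits within the scatter of both compound 2 and compound 1, so no order among these three can be claimed.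

Compound 4, `O=C(Nc1ccc(NS(=O)(=O)C(F)(F)F)c(Cl)c1)c1cccc(C(F)(F)F)c1`, is still to be measured. It differs from compound 3 by trifluoromethyl in place of ethyl on a sulfonyl sulfur. The place of the change is described in the same words for both pairs, so this is the same change made on the core of compound 3. Within the data shown here, a step close to the earlier one is expected, a 3.0-fold lower number from compound 3 to compound 4 (0.47 log units; beyond the scatter), because a 3.0-fold lower number from compound 1 to compound 2 (0.48 log units; beyond the scatter) is the only measured instance of this change. Compound 4 is therefore estimated at about 21000 nM, with a likely range from 9000 nM to 48000 nM.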

Compound 4, half-maximal inhibitory concentration: 55800 nM
For compound 4 the middle estimate is 2.7-fold (0.42 log units) below the measured one; measured number above the stated range.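

In this assay the step on the second core is a 1.1-fold lower number from compound 3 to compound 4 (0.05 log units; within the scatter) and so stays within the usual scatter, which means that the swap of ethyl for trifluoromethyl on the sulfonyl sulfur gives no clear change on the core of compound 3. The same swap therefore did not carry its size from one core to the other: the same change on two cores in this assay, a 3.0-fold lower number (0.48 log units; beyond the scatter) from compound 1 to compound 2 and a 1.1-fold lower number (0.05 log units; within the scatter) from compound 3 to compound 4, 2.7-fold (0.44 log units) apart, beyond the scatter of two such steps. Among these compounds, with only two pairs, this shows that the size of the step is not fixed, but it does not show which part of the cores matters or how the swap would behave on a further core.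

The compounds shown leave open whether a longer chain such as propyl on the sulfonyl sulfur would fall in line with either step. They also leave open how an amine in place of the sulfonamide would compare on these two cores.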